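Urea Substituent Change on the Shared Core

The source may hold more compounds than are shown below. What is called first, only, known or untested is meant among the compounds shown, and "the series" means these compounds.

Measured so far:
- compound 1 `COc1ncc(-c2ccc3nc(NC(=O)NC4CC4)nn3c2)cc1NS(=O)(=O)c1ccc(F)cc1`: 90 nM
- compound 2 `CCN(CC)CCNC(=O)Nc1nc2ccc(-c3cnc(OC)c(NS(=O)(=O)c4ccc(C)cc4)c3)cn2n1`: 170 nM

In a functional assay on HCT-116 cells (Homo sapiens) for cytotoxicity, read by MTT assay, with a stated time of 72 h (a lower number here means a stronger inhibitor, a higher number a weaker inhibitor), compound 1 gives the lower of the two numbers recorded, but compound 2 sits within the scatter of it, so the two are not separated. Going by the values given here, no step between measured compounds differing in a single place is available, so the size of a change at the urea end of the shared core is unknown.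

Compound 3 `COc1ncc(-c2ccc3nc(NC(=O)NCC(=O)N4CCCCC4)nn3c2)cc1NS(=O)(=O)c1ccc(F)cc1` is the next compound, differing from compound 1 in one place: ((piperidin-1-yl)carbonyl)methyl in place of cyclopropyl on an amide-type nitrogen. Among the compounds with values here, with only two measured compounds, neither differing from compound 3 in a single place, nothing anchors the expectation. The step in this assay from compound 1 to compound 3 is expected to be small, at most a modest move toward a higher number, a 1.7-fold higher number from compound 1 to compound 3 (0.22 log units; within the scatter). Compound 3 is therefore estimated at 150 nM in this assay, with a range of 50 nM to 450 nM.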

Compound 3, half-maximal inhibitory concentration: 130 nM
Estimate against measurement, compound 3: 1.2-fold (0.06 log units) above; low and high end bracket the measured number.
By their numbers in this assay, from the lowest: compounds 1, 3 and 2 (each within the scatter of the next).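

In this assay, the urea end of the shared core now has its first single-place step: ((piperidin-1-yl)carbonyl)methyl in place of cyclopropyl on the amide-type nitrogen gives a 1.4-fold higher number from compound 1 to compound 3 (0.16 log units; within the scatter) for this pair. At this nitrogen, a group of 9 heavy atoms with a six-membered non-aromatic ring and a hydrogen-bond acceptor is therefore not separated from a three-membered ring of 3 heavy atoms. No measurement at hand accounts for this outcome.

Still open, from the compounds shown here alone, is whether a carboxylic acid or a primary amine at the end of the methyl-linked chain, in place of the piperidine amide, would give a step beyond the scatter. A methyl group or a longer alkyl chain on the same nitrogen is equally unresolved.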